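This account rests on a few compounds, and the source may have more. Where it says the series, first, only, none or still open, it means among the compounds named here.

Measured in a functional assay on MCF7 cells (Homo sapiens) for antiproliferative activity, read by sulforhodamine B assay, with a stated time of 48 h; on this read-out lower numbers stand for stronger inhibition and higher numbers for weaker inhibition:
- compound 1 `COc1cccc(/C=C/C(=O)/C=C(O)/C=C/c2cccc(OC)c2OC)c1OC`: > 50000 nM (a limit)
- compound 2 `COc1cccc(/C=C/C(=O)C(=Cc2cc(OC)c(OC)c(OC)c2)C(=O)/C=C/c2cccc(OC)c2OC)c1OC`: 840 nM

Compound 1 gives only a limit, > 50000 nM, not a number. Among the measured compounds shown here, that leaves compound 2 with the only true number so far, 840 nM. Compound 3 `COc1cccc(/C=C/C(=O)C(=Cc2ccc(O)c(F)c2)C(=O)/C=C/c2cccc(OC)c2OC)c1OC` has 3-fluoro-4-hydroxyphenyl in place of 3,4,5-trimethoxyphenyl on a double-bonded chain carbon bound to a double-bonded chain carbon. For the measured compounds named here, no measured step shows what this swap does, so the only anchor is compound 2 at 840 nM. A small change in this assay is expected, slightly weaker if anything and probably within the scatter, with the estimate being a 1.2-fold higher number from compound 2 to compound 3 (0.08 log units; within the scatter). Compound 3 is estimated at 1000 nM, with an expected range of 250 nM to 4000 nM.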

Compound 3, half-maximal inhibitory concentration: 300 nM
Compound 3: the middle estimate sits 3.3-fold (0.52 log units) above what was measured; the range from low to high includes it.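

In this assay, the swap on a double-bonded chain carbon bound to a double-bonded chain carbon gives a 2.8-fold lower number from compound 2 to compound 3 (0.45 log units; beyond the scatter), a modest gain. So activity here does not depend on 3,4,5-trimethoxyphenyl: 3-fluoro-4-hydroxyphenyl, which brings a hydrogen-bond donor the old group lacked, serves better. Nothing measured here explains why.

Going by these compounds, the swap replaces the methoxy groups and adds fluorine and hydroxyl all at once, so which of these changes matters stays open. How a plain phenyl, or a phenyl carrying an amine or a carboxylic acid, would behave at this position is also unknown.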